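Extending the amide chain: cytotoxicity limits across the series

The source may hold more compounds than are shown below. What is called first, only, known or untested is meant among the compounds shown, and "the series" means these compounds.

Measured compounds in an ADME assay on P388D1 cells (Mus musculus) for cytotoxicity, read by fluorescence and resazurin assay, with a stated time of 72 h; on this read-out higher numbers stand for weaker inhibition and lower numbers for stronger inhibition:
Compound 1 `O=C(CCC1CCCCC1)Nc1ncc(Cc2cccc3sccc23)s1` gives only a limit, > 40000 nM.
Compound 2 `O=C(Nc1ncc(Cc2cccc3sccc23)s1)C1CCCCC1` gives only a limit, > 40000 nM.
Compound 3 `O=C(Nc1ncc(Cc2cccc3ccoc23)s1)C1CCCCC1` gives only a limit, > 40000 nM.

All three values sit at the limit of > 40000 nM in this assay, at which 3 of the 3 values shown sit, so none of them is a number. Compound 2 and compound 1 differ in one place: 2-cyclohexylethyl in place of cyclohexyl on a carbonyl carbon. The step that the two limits leave unreadable from compound 2 to compound 1 cannot be read, because the limit of > 40000 nM in this assay, at which 3 of the 3 values shown sit, caps both ends of it. Compound 3 carries a different core from compound 2; the difference between the two cores is not broken down here. Compound 4 `O=C(CCC1CCCCC1)Nc1ncc(Cc2cccc3ccoc23)s1` stands to compound 3 as compound 1 stands to compound 2: 2-cyclohexylethyl in place of cyclohexyl on a carbonyl carbon. The two place lines are the same word for word, so this is the same change made a second time in the series.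

Beside the unreadable earlier step, the step from compound 3 to compound 4 is expected to be a step that the limit leaves unreadable from compound 3 to compound 4, an expectation that rests on the earlier pair both sitting at the limit of > 40000 nM in this assay, at which 3 of the 3 values shown sit, with nothing readable between them. Compound 4 is expected to come out around 60000 nM, most likely reported once more as a limit rather than a number, within a range of 20000 nM to 200000 nM.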

Compound 4, half-maximal inhibitory concentration: 17800 nM
Estimate against measurement, compound 4: 3.4-fold (0.53 log units) above; measured number outside the range, below it.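

In this assay, 2-cyclohexylethyl in place of cyclohexyl on a carbonyl carbon gives an at least 2.2-fold lower number from compound 3 to compound 4 (0.35 log units; beyond the scatter), so the change has a readable result on the core of compound 3, although the true size of the step may be larger than this figure. Compound 2 and compound 1 both sit at a limit and not at a number, so the same change on their shared core cannot be read: the limit of > 40000 nM in this assay, at which 3 of the 4 values shown sit. The series therefore does not show that the lower number carries from one core to the other, nor that it fails to carry, and a single readable pair gives no general rule for this change.

Still open, from the compounds shown here alone, is whether a longer chain in place of 2-cyclohexylethyl on a carbonyl carbon would take the number lower still on the core of compound 3. Also open, going by these compounds, is whether such a chain would bring the core of compound 2 to a readable number in this assay.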